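A few compounds are considered here, and "the series" means these few. Any claim that something is new, unique, unknown or untested is made for them only; others in the source may bear on it.

Measured in a functional assay on HL-60 cells (Homo sapiens) for antiproliferative activity, read by XTT assay, with a stated time of 72 h; on this read-out higher numbers stand for weaker inhibition and lower numbers for stronger inhibition:

- Compound 1 `C#Cc1cn([C@@H]2O[C@H](CO)[C@@H](O)[C@H]2O)c2ncnc(OC)c12`: 190 nM
- Compound 2 `CSc1ncnc2c1c(-c1ccccc1)cn2[C@@H]1O[C@H](CO)[C@@H](O)[C@H]1O`: > 20000 nM

Compound 2 gives > 20000 nM, which is a limit of this assay and not a number. The next compound, compound 3 `C#Cc1cn([C@@H]2O[C@H](CO)[C@@H](O)[C@H]2O)c2ncnc(SC)c12`, has ethynyl in place of phenyl on an aromatic carbon of the five-membered aromatic ring: ethynyl in place of phenyl on an aromatic carbon. Within the data shown here, no pair of measured compounds shows this swap on its own, so the expectation rests on a single comparison. Compound 1 also carries ethynyl, and it gives 190 nM. A large move towards stronger inhibition is therefore expected, well beyond the usual scatter, and the estimated change is an at least 110-fold lower number from compound 2 to compound 3 (2.07 log units; beyond the scatter). For compound 3 the expected value is 170 nM, with an estimated range of 35 nM to 1200 nM.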

Compound 3, half-maximal inhibitory concentration: 50 nM
Beside the measured number, compound 3's estimate is 3.4-fold (0.53 log units) above it, within the range that was stated.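

In this assay, this aromatic carbon of the five-membered ring is now shown on its own to matter greatly: ethynyl in place of phenyl gives an at least 400-fold lower number from compound 2 to compound 3 (2.60 log units; beyond the scatter). The full size of that step cannot be read, since compound 2 stands at a limit and not at a number: the limit of > 20000 nM in this assay, at which 1 of the 3 values shown sits. The other single change, methylsulfanyl in place of methoxy on an aromatic carbon with ethynyl held in place, is much smaller, with a 3.8-fold lower number from compound 1 to compound 3 (0.58 log units; beyond the scatter).

The compounds shown leave open how a nitrile, an amine or a longer chain ending in a triple bond would fare on this carbon. They also leave open whether phenyl gives the same loss when methoxy replaces methylsulfanyl.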